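The source may hold more compounds than are shown below. What is called first, only, known or untested is meant among the compounds shown, and "the series" means these compounds.

Measured so far:
- Compound 1 `CC1=NN(C(=O)CCl)C(c2cc(Br)ccc2O)C1`: 12300 nM
- Compound 2 `CC1=NN(S(=O)(=O)c2ccc([N+](=O)[O-])cc2)C(c2cc(Br)ccc2O)C1`: > 60000 nM
- Compound 3 `CC1=NN(S(=O)(=O)c2ccc(F)cc2)C(c2cc(Br)ccc2O)C1`: 50100 nM

These values come from a functional assay on HepG2 cells (Homo sapiens) for antiproliferative activity, read by MTT assay, with a stated time of 48 h; on this read-out lower numbers stand for an effect already at smaller amounts and higher numbers for an effect only at larger amounts of compound. Compound 2 reads > 60000 nM, which is a limit and not a number. Of the two true numbers, compound 3 has the higher at 50100 nM, while compound 1 has the lower at 12300 nM.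

Compound 4 `CC1=NN(S(=O)(=O)c2ccccc2I)C(c2cc(Br)ccc2O)C1` changes the group on the sulfonyl sulfur of compound 3: 2-iodophenyl in place of 4-fluorophenyl on a sulfonyl sulfur. In words, 2-iodophenyl takes the place of 4-fluorophenyl on a sulfonyl sulfur.

Among the compounds with values here, only one measured step touches this group: an at least 1.1-fold lower number from compound 2 to compound 3 (0.07 log units; that floor lies within the scatter). That single step gives no sign that swapping the group moves the number far in this assay, so no change beyond the scatter is expected here. The expected step is a 1.3-fold lower number from compound 3 to compound 4 (0.10 log units; within the scatter). Compound 4 could also meet the same ceiling: the limit of > 60000 nM in this assay, at which 1 of the 3 values shown sits.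

For compound 4 the estimate is 40000 nM, with an expected range of 17000 nM to 60000 nM.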

Compound 4, half-maximal effective concentration: > 60000 nM
Compound 4: no number, only a limit (the forecaster's own chance of this, stated with the estimate: 35%); at least 1.5-fold (0.17 log units) between middle value and limit.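

In this assay, going by these compounds, 2-iodophenyl in place of 4-fluorophenyl on a sulfonyl sulfur gives an at least 1.1-fold higher number from compound 3 to compound 4 (0.07 log units; that floor lies within the scatter), and only that floor can be read, so the true size of the step stays unknown. Compound 4 reads > 60000 nM, which is a limit of the assay and not a number. This makes compound 3 the only compound shown with a group on the sulfonyl sulfur that has a true number, while the sulfonyl compounds compound 2 and compound 4 both sit at the ceiling: the limit of > 60000 nM in this assay, at which 2 of the 4 values shown sit.

Compound 2 and compound 4 cannot be ordered against each other, since neither has a true number. On these data alone, how a 4-iodophenyl, a 4-aminophenyl or a plain methyl on the sulfonyl sulfur would read remains open.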